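Working notes on compounds 1 to 4

The compounds below may be only part of what the source reports. "The series", "measured", "known", "first", "only" and "open" are said of these compounds alone.

Compound 1 `Nc1nc(=O)ccn1[C@@H]1O[C@H](COP(=O)(O)OP(=O)(O)O)[C@@H](O)[C@H]1O` gives 604 nM in an in vitro functional assay on 1321-N1 cells for agonist activity at P2Y purinoceptor 2 (Homo sapiens), read by scintillation proximity assay and inositol phosphate accumulation; a higher number here means that more compound is needed for the effect, a lower number that less compound is needed. Compound 2 `CSc1nc(=O)ccn1[C@@H]1O[C@H](COP(=O)(O)OP(=O)(O)O)[C@@H](O)[C@H]1O` gives 523 nM; the move from compound 1 to compound 2 is a 1.2-fold lower number from compound 1 to compound 2 (0.06 log units; within the scatter). Compound 3 `CCSc1nc(=O)ccn1[C@@H]1O[C@H](COP(=O)(O)O)[C@@H](O)[C@H]1O` gives 1500 nM, the highest of the three numbers, beyond the scatter from both compound 1 and compound 2. Compound 4 `CNc1nc(=O)ccn1[C@@H]1O[C@H](COP(=O)(O)O)[C@@H](O)[C@H]1O` is not yet measured; it differs from compound 3 by methylamino in place of ethylsulfanyl on an aromatic carbon. Among the compounds with values here, the only measured step that bears on swapping a sulfur-linked group for a nitrogen-linked group is a 1.2-fold lower number from compound 1 to compound 2 (0.06 log units; within the scatter), within the scatter, so no step beyond the scatter is expected in this assay in either direction. Compound 4 is therefore expected to give about 1400 nM, within 500 nM to 4000 nM. That expectation amounts to a 1.1-fold lower number from compound 3 to compound 4 (0.03 log units; within the scatter).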

Compound 4, half-maximal effective concentration: > 100000 nM
Compound 4: only a limit was reported (the forecaster's own chance of this, stated with the estimate: 5%); middle value at least 71-fold (1.85 log units) away from the limit.
By their numbers in this assay, from the lowest: compounds 2 and 1 (each within the scatter of the next); then compound 3. At a limit, above all of these: compound 4.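

In this assay, methylamino in place of ethylsulfanyl between two ring nitrogen atoms is far from neutral at this position: an at least 66-fold higher number from compound 3 to compound 4 (1.82 log units; beyond the scatter). Compound 4 is reported only as a limit, not a number: the limit of > 100000 nM in this assay, at which 1 of the 4 values shown sits. The earlier change, a 1.2-fold lower number from compound 1 to compound 2 (0.06 log units; within the scatter), stays within the scatter, but it stands on the core of compound 1, so this position's tolerance depends on the groups compared or on the rest of the molecule.

On these data alone, whether the nitrogen link or the shorter chain drives the step stays open. An ethylamino group on the core of compound 3 would separate the two.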